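Amide-nitrogen aryl exchange: compound 2 to compound 3

The compounds below may be only part of what the source reports. "The series", "measured", "known", "first", "only" and "open" are said of these compounds alone.

Among the compounds with values here, in an ADME assay on MT4 cells (Homo sapiens) for cytotoxicity, read by MTT assay (on this read-out lower numbers stand for higher toxicity in this test and higher numbers for lower toxicity in this test), compound 1 (`CC(=O)c1ccc(NC(=O)CSc2nncnc2-c2cccc3ccccc23)c(Br)c1`) gives 133000 nM and compound 2 (`O=C(CSc1nncnc1-c1cccc2ccccc12)Nc1ccccc1Br`) gives 87000 nM, so compound 2 cannot be separated from the only other measured compound. Compound 3 (`O=C(CSc1nncnc1-c1cccc2ccccc12)Nc1ccc([N+](=O)[O-])cc1Cl`) differs from compound 2 as follows: 2-chloro-4-nitrophenyl in place of 2-bromophenyl on an amide-type nitrogen. Within the data shown here, the sole measured step, a 1.5-fold lower number from compound 1 to compound 2 (0.18 log units; within the scatter), is hydrogen in place of acetyl on an aromatic carbon, elsewhere in the aryl group. It stays within the scatter but does not test this exchange directly, so no shift beyond the scatter is expected in this assay. The estimated step is a 1.0-fold higher number from compound 2 to compound 3 (0.01 log units; within the scatter). Compound 3 is expected at 90000 nM, with an estimated range of 30000 nM to 200000 nM.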

Compound 3, half-maximal cytotoxic concentration: 150000 nM
Beside the measured number, compound 3's estimate is 1.7-fold (0.22 log units) below it; the measured number falls inside the stated range.
By their numbers in this assay, from the lowest: compounds 2, 1 and 3 (each within the scatter of the next).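

In this assay, the change on the amide-type nitrogen stays within the scatter both for 2-chloro-4-nitrophenyl in place of 2-bromophenyl, a 1.7-fold higher number from compound 2 to compound 3 (0.24 log units; within the scatter), and for 2-chloro-4-nitrophenyl in place of 4-acetyl-2-bromophenyl, a 1.1-fold higher number from compound 1 to compound 3 (0.05 log units; within the scatter). This position therefore takes a whole-group exchange, including a nitro group and a different halogen, without separating the three compounds. No measured evidence bears on the reason for these numbers.

Going by these compounds, the separate contributions of the chlorine and the nitro group remain open. So does whether an amine or a carboxylic acid on this aryl group, or a longer alkyl chain in its place, would move the number beyond the scatter.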